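The compounds below may be only part of what the source reports. "The series", "measured", "known", "first", "only" and "open" are said of these compounds alone.

Working notes on the series. All four members share one core; they differ only in what the aromatic ring carries. Compound 1 `Cc1ccc(CCCCCC(=O)N2CCOC2=O)cc1C` bears two methyl groups on that ring, and in an assay on HEK293 cells for inhibition of N-acylethanolamine-hydrolyzing acid amidase (Rattus norvegicus), read by LC-MS, with a stated time of 30 min (a higher number here means a weaker inhibitor, a lower number a stronger inhibitor), compound 1 gives only a limit of the assay, > 20000 nM. Compound 2 `O=C(CCCCCc1ccc(O)c(Cl)c1)N1CCOC1=O` pairs a hydroxy with a chloro on the ring, and in this assay compound 2 also returns a limit rather than a number, > 20000 nM. Among the compounds with values here, compound 3 `O=C(CCCCCc1cccc(O)c1)N1CCOC1=O` carries a single hydroxy and is the one member resolved to a number: in this assay compound 3 gives 8640 nM, so it stands as the only measured value in the set, the other two entries being described by the limit of > 20000 nM in this assay, at which 2 of the 3 values shown sit.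

Compound 4 `NC(=O)c1cccc(CCCCCC(=O)N2CCOC2=O)c1` keeps the chain, the aromatic ring and the rest of the core and differs from compound 3 by carbamoyl in place of hydroxy on an aromatic carbon. Within the data shown here, no measured pair in the set makes this change, so nothing in the data sizes it. The expectation for this assay is a modest step toward weaker inhibition, with a fair chance that the result falls back to a limit. For compound 4 the estimated value in this assay is 13000 nM, with a range from 4000 nM to 40000 nM. The expected step is a 1.5-fold higher number from compound 3 to compound 4 (0.18 log units; within the scatter).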

Compound 4, half-maximal inhibitory concentration: > 20000 nM
Compound 4 gave a limit, no number; the forecaster's own chance of this, stated with the estimate: 35%; middle value at least 1.5-fold (0.18 log units) from the limit.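

Working from the single hydroxy of compound 3, this is the first measured pair in the series: on an aromatic carbon, meta to a large group, carbamoyl in place of hydroxy gives an at least 2.3-fold higher number from compound 3 to compound 4 (0.36 log units; beyond the scatter). In this assay compound 4 gives > 20000 nM, which is a limit of the assay and not a number, so the printed step sets only a lower bound on the size of this change. The carbamoyl therefore does not retain the resolved value of compound 3, which remains the only member of the series with a number, and the series now sits largely at one boundary: the limit of > 20000 nM in this assay, at which 3 of the 4 values shown sit.

From the compounds shown here alone, how far compound 4 lies past that limit stays unknown, and this one pair does not size any other replacement at this position. Going by these compounds, whether an amine, a carboxylic acid or a methoxy in place of the hydroxy would give a number in this assay, and how a longer chain on the shared core would change compound 3, remain open.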